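The source may report more compounds than this note shows. Statements on the series, on what has been measured and on what is new or still open speak of the compounds shown alone.

Compound 1 `O=C1C(=Cc2cccc(Cl)c2)C(=O)N(c2ccc(Cl)cc2)N1c1ccc(Cl)cc1`: 14400 nM
Compound 2 `COc1ccc(C=C2C(=O)N(c3ccc(Cl)cc3)N(c3ccc(Cl)cc3)C2=O)cc1OC`: > 128000 nM

Both compounds were tested in a functional assay on MGC-803 cells (Homo sapiens) for cytotoxicity, read by MTT assay, with a stated time of 72 h; a lower number here means a stronger inhibitor, a higher number a weaker inhibitor. Compound 2 reads > 128000 nM, which is a limit of the assay and not a number. For the measured compounds named here, its true position is therefore unknown, and it is the one compound of the pair at the limit of > 128000 nM in this assay, at which 1 of the 2 values shown sits.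

The next compound is compound 3 `O=C1C(=Cc2ccco2)C(=O)N(c2ccc(Cl)cc2)N1c1ccc(Cl)cc1`, with the change (furan-2-yl in place of 3,4-dimethoxyphenyl on a double-bonded chain carbon bound to a double-bonded ring carbon).

Going by the values given here, only one measured step bears on this place: an at least 8.8-fold higher number from compound 1 to compound 2 (0.94 log units; beyond the scatter). That step brought in the 3,4-dimethoxyphenyl that compound 3 now gives up, and it lies beyond the scatter. It involves a different incoming group, so it is only a loose guide to furan-2-yl. On that single step, a lower number is expected in this assay, with an estimated at least 3.2-fold lower number from compound 2 to compound 3 (0.50 log units; beyond the scatter). For compound 3 the expected value is 40000 nM, within an estimated range of 10000 nM to 128000 nM.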

Compound 3, half-maximal inhibitory concentration: 12800 nM
For compound 3 the middle estimate is 3.1-fold (0.49 log units) above the measured one; low and high end bracket the measured number.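

In this assay, the drop in reading on a double-bonded chain carbon bound to a double-bonded ring carbon is not tied to a chlorinated ring, since furan-2-yl also gives a measurable value: an at least 10-fold lower number from compound 2 to compound 3 (1.00 log units; beyond the scatter). Compound 2 reads a limit and not a number, so that step has only a bound: the limit of > 128000 nM in this assay, at which 1 of the 3 values shown sits. Furan-2-yl and 3-chlorophenyl are not told apart at this place (a 1.1-fold lower number from compound 1 to compound 3 (0.05 log units; within the scatter)), so among the three compounds, only compound 2, with 3,4-dimethoxyphenyl, stands apart.

On these data alone, whether a lone methoxy group on the phenyl ring would shift the reading as 3,4-dimethoxyphenyl does remains open. As far as these compounds go, how an amine or a carboxylic acid on that ring, or a plain alkyl chain in its place, would read is also open.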